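The source may report more compounds than this note shows. Statements on the series, on what has been measured and on what is new or still open speak of the compounds shown alone.

Compound 1 `O=C(O)CC(NS(=O)(=O)c1ccc(C(F)(F)F)cc1)c1ccccc1` is the reference, and in a functional assay on MDA-MB-436 cells (Homo sapiens) for antiproliferative activity, read by MTT assay, with a stated time of 24 h (on this read-out lower numbers stand for stronger inhibition and higher numbers for weaker inhibition), compound 1 gives 54700 nM. Compound 2 `O=C(O)CC(NS(=O)(=O)c1ccc(OC(F)(F)F)cc1)c1ccccc1` carries the change (trifluoromethoxy in place of trifluoromethyl on an aromatic carbon). In this assay compound 2 returns only a limit of the assay, > 100000 nM. That change gave an at least 1.8-fold higher number from compound 1 to compound 2 (0.26 log units; that floor lies within the scatter), its floor set by the limit of > 100000 nM in this assay, at which 1 of the 3 values shown sits. Compound 3 `CC(C)(C)c1ccc(C(CC(=O)O)NS(=O)(=O)c2ccc(C(F)(F)F)cc2)cc1` differs from compound 1 by tert-butyl in place of hydrogen on an aromatic carbon; in this assay compound 3 gives 60100 nM, a step of a 1.1-fold higher number from compound 1 to compound 3 (0.04 log units; within the scatter). Compound 4 `CC(C)(C)c1ccc(C(CC(=O)O)NS(=O)(=O)c2ccc(OC(F)(F)F)cc2)cc1` is unmeasured and differs from compound 3 by trifluoromethoxy in place of trifluoromethyl on an aromatic carbon, the same change made from compound 1 to compound 2, at a place described in identical words. Because compound 3 gives 60100 nM and the same change gave an at least 1.8-fold higher number from compound 1 to compound 2 (0.26 log units; that floor lies within the scatter), the step to compound 4 is expected to be a 2.0-fold higher number from compound 3 to compound 4 (0.30 log units; within the scatter). For compound 4 in this assay a value of 120000 nM is estimated, between 55000 nM and 300000 nM, with a fair chance that only a limit is reported.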

Compound 4, half-maximal inhibitory concentration: > 100000 nM
Compound 4 ended at the assay's limit (the forecaster's own chance of this, stated with the estimate: 60%); the middle value is on the limit's open side.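

In this assay, trifluoromethoxy in place of trifluoromethyl on the core of compound 3 gave an at least 1.6-fold higher number from compound 3 to compound 4 (0.22 log units; that floor lies within the scatter). Across the two cores, the change can be compared only through floors: the same change on two cores in this assay, an at least 1.8-fold higher number (0.26 log units; that floor lies within the scatter) from compound 1 to compound 2 and an at least 1.6-fold higher number (0.22 log units; that floor lies within the scatter) from compound 3 to compound 4; the limit leaves it open whether they differ. Going by these compounds, both trifluoromethoxy compounds thus end at the limit, so the outcome carried over in that sense, but the true size of the change on either core stays unknown, and the step between these two compounds cannot be read: the limit of > 100000 nM in this assay, at which 2 of the 4 values shown sit.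

The compounds shown leave open how a nitrile or a methoxy group would read at this place on the ring. They also leave open what an amide or a methyl ester in place of the carboxylic acid would give.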